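This account rests on a few compounds, and the source may have more. Where it says the series, first, only, none or still open, it means among the compounds named here.

Measured in a functional assay on WI-38 VA13 cells (Homo sapiens) for cytotoxicity; a lower number here means that less compound is needed, a higher number that more compound is needed for the effect: compound 1 `O=C(Nc1ccc2nc(NC(=O)C3CCCCC3)sc2c1)c1ccccc1Cl` gives 0.025 ug/mL and compound 2 `CC(=O)Nc1ccc2nc(NC(=O)C3CCCCC3)sc2c1` gives 2.7 ug/mL. Compound 3 `O=C(O)CCC(=O)Nc1nc2ccc(NC(=O)c3c(Cl)cccc3Cl)cc2s1` returns only a limit, > 6.6 ug/mL, in this assay.

Compound 3 therefore stands at the limit of > 6.6 ug/mL in this assay, at which 1 of the 3 values shown sits, with no number of its own. Compound 4 `CCNC(=O)Nc1nc2ccc(NC(=O)c3c(Cl)cccc3Cl)cc2s1` differs from compound 3 by ethylamino in place of 2-carboxyethyl on a carbonyl carbon. Going by the values given here, the one measured step, a 110-fold higher number from compound 1 to compound 2 (2.03 log units; beyond the scatter), concerns the other carbonyl carbon of the shared core, so no measured step covers the change from compound 3 to compound 4, and the limit on compound 3 fixes only one side of it. Going by these compounds, the ethylcarbamoyl group is untested in this assay. Compound 4 is expected to give 3 ug/mL, between 0.3 ug/mL and 20 ug/mL, meaning an expected step of an at least 2.2-fold lower number from compound 3 to compound 4 (0.34 log units; beyond the scatter), with a real chance of another limit.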

Compound 4, half-maximal effective concentration: 0.032 ug/mL
Compound 4: middle estimate off by 94-fold (1.97 log units), on the high side; measured number outside the range, below it.
By their numbers in this assay, from the lowest: compounds 1 and 4 (each within the scatter of the next); then compound 2. At a limit, above all of these: compound 3.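

Replacing 2-carboxyethyl with ethylamino on this carbonyl carbon gives an at least 200-fold lower number from compound 3 to compound 4 (2.31 log units; beyond the scatter) in this assay, the only measured change at this position among the compounds shown. Compound 3 stands at a limit, so this step has a bound and not an exact size: the limit of > 6.6 ug/mL in this assay, at which 1 of the 4 values shown sits.

The compounds shown leave open whether the step follows the loss of the carboxylic acid or the arrival of the ethylamino group. A plain propyl chain or a methyl ester on the same carbonyl carbon would separate the two.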